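A few compounds are considered here, and "the series" means these few. Any claim that something is new, unique, unknown or untested is made for them only; others in the source may bear on it.

The series shares one core that carries an aromatic-amine substituent, and three of its members have been tested in a physicochemical assay for solubility, read by HPLC, using the shake flask method, measured as kinetic solubility, with a stated time of 2 h, at pH 7.4; on this read-out higher numbers stand for higher solubility and lower numbers for lower solubility. Compound 1 `Cc1ccc(-c2cnn3c(NCc4ccccn4)cc(C)nc23)cc1` reaches only the limit of the assay, giving < 5000 nM in this assay. Compound 3 `Cc1cc(NCc2ccccn2)n2ncc(-c3ccc(N(C)C)cc3)c2n1` likewise sits at the limit, with < 5000 nM in this assay. The step that the two limits leave unreadable from compound 1 to compound 3 cannot be read; both of its ends rest on the same limit. As far as these compounds go, compound 2 `Cc1cc(Nc2ccccn2)n2nc(C)c(-c3ccccc3)c2n1`, the starting point of the step followed here, also returns only the limit, < 5000 nM in this assay, so its standing against the others is unknown beyond the fact that all three rest there (the limit of < 5000 nM in this assay, at which 3 of the 3 values shown sit). The step goes from compound 2 to compound 4 `Cc1cc(NCc2ncnn2C)n2nc(C)c(-c3ccccc3)c2n1`, in which ((1-methyl-1H-1,2,4-triazol-5-yl)methyl in place of pyridin-2-yl on a nitrogen on an aromatic ring). Going by the values given here, no measured pair in the set covers this kind of change, and the one measured step is unreadable, so no sized expectation in either direction can be drawn from the data. Given that every value sits on the limit (the limit of < 5000 nM in this assay, at which 3 of the 3 values shown sit), compound 4 is expected to give 6000 nM, in the range 1500 nM to 25000 nM. This corresponds to an expected step of an at least 1.2-fold higher number from compound 2 to compound 4 (0.07 log units; that floor lies within the scatter), and the result may well itself come back only as a limit.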

Compound 4, solubility: 185000 nM
For compound 4 the middle estimate is 31-fold (1.49 log units) below the measured one, outside the stated range (above it).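

Going by these compounds alone, at the nitrogen on an aromatic ring, the change from (pyridin-2-yl)amino to ((1-methyl-1H-1,2,4-triazol-5-yl)methyl)amino gives, in this assay, an at least 37-fold higher number from compound 2 to compound 4 (1.56 log units; beyond the scatter); this is the first step that can be read, as the earlier step rests on limits at both ends and cannot be read. In this assay compound 2 gives < 5000 nM, which is a limit of the assay. Compound 4 is the only compound shown that stands clear of the limit on which the others rest: the limit of < 5000 nM in this assay, at which 3 of the 4 values shown sit.

The change replaces the six-membered ring with a five-membered ring and also sets a methylene link on the nitrogen, so the compounds shown leave open how much of the step belongs to the ring and how much to the link, a question that (pyridin-2-yl)methyl on the core of compound 2 would address directly. They also leave open how other groups at this nitrogen would read, such as (1-methyl-1H-imidazol-2-yl)methyl or a longer chain ending in a dimethylamino group.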